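The compounds below may be only part of what the source reports. "The series", "measured", "known", "first", "only" and "open" are said of these compounds alone.

Of the compounds shown here, three have been measured in a physicochemical assay for lipophilicity, read by HPLC, measured as chromatographic lipophilicity, at pH 7.4; a lower number here means a more polar compound, a higher number a more lipophilic compound. Compound 1 `O=C(C1CCCCC1)N1CCC(C(=O)N2N=CCC2c2ccccc2)CC1` gives 5.4 in this assay. Compound 2 `CC(C)(C)C(=O)N1N=CCC1c1cccc(F)c1` gives 5.9. Compound 3 `Cc1ccc(C2CC=NN2C(=O)C(C)(C)C)cc1F` gives 6.6, the highest of the three numbers, with compound 2 nearest and compound 1 furthest. Within the data shown here, the only step between measured compounds that differ in a single place, a number 0.70 log units higher from compound 2 to compound 3 (beyond the scatter), was modest but beyond the scatter.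

Compound 4 `Cc1ccc(C2CC=NN2C(=O)C(C)(C)C)cc1` has not yet been measured. It differs from compound 3 in one place: hydrogen in place of fluoro on an aromatic carbon. Among the measured compounds shown here, no measured step removes a fluoro group, so the methyl step is the only comparison available, and it describes a different change. A smaller movement is expected here than in a number 0.70 log units higher from compound 2 to compound 3 (beyond the scatter), since the change removes a single heavy atom rather than adding one. The step of a number 0.30 log units lower from compound 3 to compound 4 (within the scatter) is therefore expected to be a small fall, close to the scatter. Compound 4 is estimated at 6.3, with a range from 5.9 to 6.7.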

Compound 4, distribution coefficient: 6.4
The estimate for compound 4 lay 0.10 log units below the measured number; low and high end bracket the measured number.
By their numbers in this assay, from the lowest: compound 1; then compound 2; then compounds 4 and 3 (each within the scatter of the next).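

Replacing the fluoro with hydrogen on this aromatic carbon, ortho to a methyl group, gives a number 0.20 log units lower from compound 3 to compound 4 (within the scatter) in this assay, so the two compounds cannot be told apart in this assay. Among these compounds, this is the first measured step involving the fluoro group, and unlike a number 0.70 log units higher from compound 2 to compound 3 (beyond the scatter), it does not go beyond the usual scatter. Nothing shown here explains why one single-atom change stays within the scatter while the other goes beyond it.

As far as these compounds go, whether a different group on this carbon, such as an amine or a methoxy group, would give a step beyond the scatter remains open. Also open, from the compounds shown here alone, is whether the same exchange of fluoro for hydrogen would give a similar step in compound 2, which has no methyl group.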